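From a Methyl to a Fluorine on the Benzyl Arm

This account rests on a few compounds, and the source may have more. Where it says the series, first, only, none or still open, it means among the compounds named here.

Of the compounds shown here, two sharing one core have so far been tested in a functional assay on MGC-803 cells (Homo sapiens) for inhibition, read by MTT assay, with a stated time of 72 h; a higher number here means a weaker inhibitor, a lower number a stronger inhibitor. Compound 1 `O=C(OCc1ccccc1)N1CCN(C(=S)SCc2cn(Cc3ccc(Cl)cc3)nn2)CC1` gives 31300 nM. Among the measured compounds shown here, compound 2 `Cc1ccc(Cn2cc(CSC(=S)N3CCN(C(=O)OCc4ccccc4)CC3)nn2)cc1` gives 9370 nM, the lower of the two numbers; the single recorded step, a 3.3-fold lower number from compound 1 to compound 2 (0.52 log units; beyond the scatter), is modest but lies beyond the scatter. Compound 3 `O=C(OCc1ccccc1)N1CCN(C(=S)SCc2cn(Cc3ccccc3F)nn2)CC1` has not yet been measured. It differs from compound 2 by 2-fluorophenyl in place of 4-methylphenyl on a saturated chain carbon bound to an aromatic nitrogen. For the measured compounds named here, the one measured step bears on this change only loosely: it exchanged a chloro for a methyl, whereas the new change removes the methyl and brings in a fluorine as part of a 2-fluorophenyl, so a halogen returns to the ring but in a different group. A rise in the number is expected because compound 1, the halogen-bearing compound, gives 31300 nM, though the rise may fall short of that value since the group is not the same. The estimate for compound 3 is 20000 nM, with a range from 6000 nM to 60000 nM. This corresponds to an expected step of a 2.1-fold higher number from compound 2 to compound 3 (0.33 log units; beyond the scatter).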

Compound 3, half-maximal inhibitory concentration: 5060 nM
For compound 3 the middle estimate is 4.0-fold (0.60 log units) above the measured one; measured number outside the range, below it.
By their numbers in this assay, from the lowest: compounds 3 and 2 (each within the scatter of the next); then compound 1.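

Replacing the 4-methylbenzyl group with 2-fluorobenzyl gives a 1.9-fold lower number from compound 2 to compound 3 (0.27 log units; within the scatter) in this assay, so compound 2 and compound 3 cannot be told apart here, and carrying a halogen on this benzyl arm does not by itself place a compound with the weaker compound 1. The halogen-bearing pair does separate, with a 6.2-fold lower number from compound 1 to compound 3 (0.79 log units; beyond the scatter) on going from 4-chlorophenyl to 2-fluorophenyl at the same saturated chain carbon, so the readout at this position depends on more than whether a halogen is present. No measurement is available to explain why these groups differ in this way.

Compound 1 and compound 3 differ in both the halogen and its place on the ring, so the compounds shown cannot say which of the two accounts for the step between them; the 2-chlorophenyl and 4-fluorophenyl groups would pull these two apart. On these data alone, it also remains open how this position responds to a ring carrying something other than a methyl or a halogen, such as an amine or a carboxylic acid.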